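Methoxy on the anilide of compound 1

The source may hold more compounds than are shown below. What is called first, only, known or untested is meant among the compounds shown, and "the series" means these compounds.

Compound 1, `CCn1c(CNc2ccccc2)nnc1SCC(=O)Nc1ccccc1`: > 10000 nM
Compound 2, `CCC(=O)c1ccc2nc(CSc3nnc(CNc4ccccc4)n3CC)oc2c1`: 1200 nM

Of the compounds shown here, two have been measured in an assay on isolated protein for inhibition of long-chain fatty acid transport protein 1 (Mus musculus); a lower number here means a stronger inhibitor, a higher number a weaker inhibitor. Compound 1 `CCn1c(CNc2ccccc2)nnc1SCC(=O)Nc1ccccc1` reaches only the limit of > 10000 nM in this assay, so no number is known for it; the value is a limit, not a measurement, and it sits at the limit of > 10000 nM in this assay, at which 1 of the 2 values shown sits. Compound 2 `CCC(=O)c1ccc2nc(CSc3nnc(CNc4ccccc4)n3CC)oc2c1` gives 1200 nM in this assay. The two compounds differ in more than one place, so nothing can be said about any single change between them beyond what their two values show.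

The step under study runs from compound 1 to compound 3 `CCn1c(CNc2ccccc2)nnc1SCC(=O)Nc1ccc(OC)cc1`. The change is methoxy in place of hydrogen on an aromatic carbon of the anilide ring. For the measured compounds named here, no measured step of this kind is available here. With compound 1 standing at a limit, a small step in either direction, or none beyond the scatter, is the expectation.

Compound 3 is therefore expected at about 15000 nM, between 4000 nM and 60000 nM, which would mean an expected step that the limit leaves unreadable from compound 1 to compound 3 in this assay.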

Compound 3, half-maximal inhibitory concentration: > 10000 nM
Compound 3 was reported as a limit; the forecaster's own chance of this, stated with the estimate: 75%; the middle value is on the limit's open side.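

In this assay compound 3 gives > 10000 nM as a limit, not a number. Compound 1 also stands at a limit, so no step between compound 1 and compound 3 can be read: the limit of > 10000 nM in this assay, at which 2 of the 3 values shown sit.

The compounds shown leave open whether methoxy in place of hydrogen on the anilide ring changes inhibition at all.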